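The source may report more compounds than this note shows. Statements on the series, on what has been measured and on what is new or still open speak of the compounds shown alone.

Compound 1 `CN1CCN(c2ccc(Nc3ncc4c(n3)N(C3CCCC3)CC(=O)N4)nc2)CC1` was tested in a functional assay on HCT-116 cells (Homo sapiens) for inhibition, read by MTT assay, with a stated time of 48 h; on this read-out lower numbers stand for stronger inhibition and higher numbers for weaker inhibition. In this assay compound 1 gives > 30000 nM, which is a limit of the assay and not a number. Compound 2 `O=C1CN(C2CCCC2)c2nc(Nc3ccc(N4CCCCC4)cn3)ncc2N1` differs from compound 1 only by piperidin-1-yl in place of 4-methylpiperazin-1-yl on an aromatic carbon. In this assay compound 2 gives > 30000 nM, likewise a limit. The step that the two limits leave unreadable from compound 1 to compound 2 therefore cannot be read, since both values lie on (the limit of > 30000 nM in this assay, at which 2 of the 2 values shown sit). Compound 3 `CCN1C(=O)CN(C2CCCC2)c2nc(Nc3ccc(N4CCN(C)CC4)cn3)ncc21` carries the change (ethyl in place of hydrogen on an amide-type nitrogen in a ring), set on an amide-type nitrogen in a ring of a six-membered non-aromatic ring with two nitrogen, part of the fused two-ring core. No measured step touches that nitrogen, and the single step shown is unreadable, so no size or direction beyond the scatter can be expected. Compound 3 is therefore estimated at 40000 nM, between 8000 nM and 150000 nM, most probably again as a limit. The expected step that the limit leaves unreadable from compound 1 to compound 3 is accordingly one of no readable size.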

Compound 3, half-maximal inhibitory concentration: 16400 nM
The estimate for compound 3 lay 2.4-fold (0.39 log units) above the measured number; low and high end bracket the measured number.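

Going by these compounds alone, with ethyl on the amide-type nitrogen in the ring, compound 3 gives 16400 nM in this assay, the first readable number in this set. Compound 1 gives > 30000 nM, which is a limit and not a number, and the one other earlier compound sits there too: the limit of > 30000 nM in this assay, at which 2 of the 3 values shown sit. The change makes an at least 1.8-fold lower number from compound 1 to compound 3 (0.26 log units; that floor lies within the scatter), so the true size of the step remains unknown, and this nitrogen is the only place shown where a change yields a readable number.

From the compounds shown here alone, whether methyl or a longer chain such as propyl on this nitrogen would give a lower or a higher number stays open. Also open, going by these compounds, is whether ethyl would yield a readable number when piperidin-1-yl stands in place of 4-methylpiperazin-1-yl.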